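Adding a dihydroxyphenyl to a nitro-bearing fused core

The source may hold more compounds than are shown below. What is called first, only, known or untested is meant among the compounds shown, and "the series" means these compounds.

Compound 2 `O=[N+]([O-])C1=CNc2nc(-c3ccco3)nn2C1`: 108000 nM
Compound 3 `O=[N+]([O-])C1=NNc2ncnn2C1c1ccc(O)cc1O`: 90000 nM
Compound 1 `O=[N+]([O-])C1=CNc2nc(C(F)(F)F)nn2C1O`: 33000 nM

All three were tested in an ADME assay on MDCK cells (Canis lupus familiaris) for cytotoxicity; on this read-out lower numbers stand for higher toxicity in this test and higher numbers for lower toxicity in this test. Compound 2 gives the highest of the three numbers; compound 3 lies within the scatter of it, while compound 1 sits beyond the scatter, at a lower number. Compound 4 `O=[N+]([O-])C1=CNc2nc(-c3ccco3)nn2C1c1ccc(O)c(O)c1` has not been measured yet. It differs from compound 2 in one place: 3,4-dihydroxyphenyl in place of hydrogen on a saturated ring carbon. Within the data shown here, no step between measured compounds is known, so the size of such a change is open. Compound 3, on a different core, carries a dihydroxyphenyl of its own and gives a number within the scatter of compound 2, which is a hint but no more. This step, a 1.4-fold lower number from compound 2 to compound 4 (0.13 log units; within the scatter), is therefore expected to stay within the scatter. Compound 4 is estimated at 80000 nM, in a range from 30000 nM to 200000 nM.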

Compound 4, half-maximal cytotoxic concentration: > 1200000 nM
Compound 4: a limit, no number; the forecaster's own chance of this, stated with the estimate: 10%; at least 15-fold (1.17 log units) between middle value and limit.
By their numbers in this assay, from the lowest: compound 1; then compounds 3 and 2 (each within the scatter of the next). At a limit, above all of these: compound 4.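

In this assay, 3,4-dihydroxyphenyl in place of hydrogen on this saturated ring carbon gives an at least 11-fold higher number from compound 2 to compound 4 (1.04 log units; beyond the scatter) and so moves towards lower toxicity in this test, showing that a change at this one position can have a large effect. Compound 4 gives > 1200000 nM as a limit of the assay and not a number. The step is therefore a minimum, and its full size cannot be read: the limit of > 1200000 nM in this assay, at which 1 of the 4 values shown sits.

Going by these compounds, whether the phenyl ring or its two hydroxyl groups drive this change remains open. So does how an unsubstituted phenyl, an amine or a carboxylic acid on this carbon would read.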